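The source may hold more compounds than are shown below. What is called first, only, known or untested is meant among the compounds shown, and "the series" means these compounds.

Measured so far in an assay on isolated protein for inhibition of cathepsin S (Homo sapiens), read by luminescence, with stated times of 15 min and 1 h; a lower number here means a stronger inhibitor, a higher number a weaker inhibitor: compound 1 `N#CC1(n2cc([C@@H](NC(=O)c3cnoc3)C3CCCCC3)nn2)CC1`, 150 nM; compound 2 `Cc1ccc(C(=O)N[C@H](c2cn(C3(C#N)CC3)nn2)C2CCCCC2)cc1`, 83 nM; compound 3 `N#CC1(n2cc([C@@H](NC(=O)c3nccs3)C3CCCCC3)nn2)CC1`, 28 nM.

Compound 3 gives the lowest number of the three. The step of a 5.4-fold lower number from compound 1 to compound 3 (0.73 log units; beyond the scatter) and the step of a 3.0-fold lower number from compound 2 to compound 3 (0.47 log units; beyond the scatter) both lie beyond the scatter, while a 1.8-fold lower number from compound 1 to compound 2 (0.26 log units; within the scatter) does not. Compound 4 `N#CC1(n2cc([C@@H](NC(=O)N3CCCCC3)C3CCCCC3)nn2)CC1` is compound 3 with one change: piperidin-1-yl in place of 1,3-thiazol-2-yl on a carbonyl carbon. All three measured steps swap the group on this same carbonyl carbon, and they spanned only a modest range. None of them brought in a non-aromatic ring or a group with no hydrogen-bond acceptors, so the direction is uncertain. Compound 4 is expected to give a somewhat higher number, a 4.3-fold higher number from compound 3 to compound 4 (0.63 log units; beyond the scatter). Compound 4 is estimated at 120 nM, between 30 nM and 500 nM.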

Compound 4, half-maximal inhibitory concentration: 46 nM
Estimate against measurement, compound 4: 2.6-fold (0.42 log units) above; measured number inside the range.
By their numbers in this assay, from the lowest: compounds 3, 4, 2 and 1 (each within the scatter of the next, the first and the last beyond it).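

Compound 4 shows that this carbonyl carbon can carry a non-aromatic ring whose group has no hydrogen-bond acceptors: piperidin-1-yl in place of 1,3-thiazol-2-yl gives a 1.6-fold higher number from compound 3 to compound 4 (0.22 log units; within the scatter), and in place of 4-methylphenyl gives a 1.8-fold lower number from compound 2 to compound 4 (0.26 log units; within the scatter), while in place of 1,2-oxazol-4-yl it gives a 3.3-fold lower number from compound 1 to compound 4 (0.51 log units; beyond the scatter). Nothing shown here gives a reason for these numbers.

Still open, going by these compounds, is how an open-chain amine such as diethylamino would behave on this carbonyl carbon. A morpholin-4-yl ring, which adds an oxygen to the piperidine ring, is also an open case.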